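The compounds below may be only part of what the source reports. "The series", "measured", "known", "first", "only" and "open" are said of these compounds alone.

Going by the values given here, compound 1, `O=C1CCCN1c1cnc(NCc2c(F)ccc3c2CCO3)c2cn[nH]c(=O)c12`, stands lowest of the two compounds measured so far in a physicochemical assay for lipophilicity, using the shake flask method, in phosphate buffer, measured as octanol-water partition, with a stated time of 30 min, at pH 7.4; on this read-out higher numbers stand for higher lipophilicity and lower numbers for lower lipophilicity: compound 1 gives 1.8. Among the compounds with values here, the only other measured compound, compound 2, `Fc1ccc2c(c1CNc1ncc(Oc3ccccc3)c3nncn13)CCO2`, gives 3.5 in this assay, a reading higher than that of compound 1 by more than the usual scatter. Compound 2 is built on a different core, so the pair says nothing about any single change. Compound 3, `Cc1ncccc1-c1cnc(NCc2c(F)ccc3c2CCO3)c2cn[nH]c(=O)c12`, has not yet been measured. It differs from compound 1 in one place: 2-methylpyridin-3-yl in place of 2-oxopyrrolidin-1-yl on an aromatic carbon. Within the data shown here, no measured pair shows this same change, so the size of the step has to be estimated. An upward step in this assay is expected, beyond the scatter, of about a number 1.00 log units higher from compound 1 to compound 3 (beyond the scatter). For compound 3, a value of 2.8 in this assay is expected, with a likely range from 2.3 to 3.4.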

Compound 3, distribution coefficient: 3
Compound 3: the middle estimate sits 0.20 log units below what was measured; the range from low to high includes it.
By their numbers in this assay, from the lowest: compound 1; then compound 3; then compound 2.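

Going by these compounds alone, on the shared core, 2-methylpyridin-3-yl in place of 2-oxopyrrolidin-1-yl gives a number 1.20 log units higher from compound 1 to compound 3 (beyond the scatter) in this assay and provides the first measured step at this position. The earlier comparison spanned two different cores, whereas this pair differs in one place, so the large step can be tied to this exchange on an aromatic carbon. No measurement shown explains why the step has this size.

The compounds shown leave open how other groups at this position, such as morpholine, a simple amine or a carboxylic acid, would read in this assay and whether the methyl group of 2-methylpyridin-3-yl contributes to the step. A single pair also cannot tell whether the same exchange would give a step of similar size on another core.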